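The source may report more compounds than this note shows. Statements on the series, on what has been measured and on what is new or still open speak of the compounds shown alone.

Measured so far in a functional assay on the whole organism for antagonist activity, with Rattus norvegicus as the target; a lower number here means that less compound is needed, a higher number that more compound is needed for the effect:
compound 1, `CN(C)c1ncnc2c1ncn2Cc1cccc(N)c1`, gives 23 mg/kg
compound 2, `CN(C)c1ncnc2c1ncn2Cc1ccccc1`, gives 15 mg/kg
compound 3, `CCCn1cnc2c(N(C)C)ncnc21`, gives 14 mg/kg

Compound 3 holds the lowest of the three numbers, but its gaps to compound 2 and to compound 1 both fall within the scatter, so the three compounds are not separated by this assay. The two connecting steps are small: a 1.5-fold lower number from compound 1 to compound 2 (0.19 log units; within the scatter), and a 1.1-fold lower number from compound 2 to compound 3 (0.03 log units; within the scatter).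

Compound 4, `CC(C)n1cnc2c(N(C)C)ncnc21`, has not yet been measured. Against compound 3 the change is isopropyl in place of propyl on an aromatic nitrogen. Going by the values given here, no measured step rearranges a chain at this position; the one step at the same nitrogen, a 1.1-fold lower number from compound 2 to compound 3 (0.03 log units; within the scatter), swapped a phenyl for an ethyl and stayed within the scatter. There is therefore no basis for expecting a shift beyond the scatter in either direction, and the step of a 1.1-fold higher number from compound 3 to compound 4 (0.03 log units; within the scatter) is estimated to stay within it. Compound 4 is expected to give about 15 mg/kg, with a range from 7 mg/kg to 32 mg/kg.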

Compound 4, dose for half-maximal effect: 11 mg/kg
Compound 4: the middle estimate sits 1.4-fold (0.13 log units) above what was measured; low and high end bracket the measured number.
By their numbers in this assay, from the lowest: compounds 4, 3, 2 and 1 (each within the scatter of the next, the first and the last beyond it).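

Isopropyl in place of propyl on an aromatic nitrogen gives a 1.3-fold lower number from compound 3 to compound 4 (0.10 log units; within the scatter) in this assay. Until now the only change at this nitrogen was the exchange of phenyl for ethyl on the chain; this result adds that the same three carbons, joined differently, also leave the number within the scatter, so across the substituents shown here this position has not yet produced a step beyond it. Nothing available on these compounds bears on the reason for this result.

Going by these compounds, it remains open whether a longer chain such as butyl, or a carboxylic acid or an amine carried on the chain at this nitrogen, would move the number beyond the scatter. The dimethylamino group is common to all the compounds, so what replacing it with a smaller amine would do is also unresolved.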